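Triazole-linked series: aryl variation on the triazole nitrogen

This account rests on a few compounds, and the source may have more. Where it says the series, first, only, none or still open, it means among the compounds named here.

Measured so far in a functional assay on HeLa cells (Homo sapiens) for inhibition, read by MTT assay, with a stated time of 24 h; on this read-out lower numbers stand for stronger inhibition and higher numbers for weaker inhibition:
compound 1 `CCOC(=O)C1=Cc2ccccc2OC1(OCc1cn(CC(=O)NC2CCCCC2)nn1)C(F)(F)F`: 11400 nM
compound 2 `CCOC(=O)C1=Cc2ccccc2OC1(OCc1cn(-c2ccc(F)c(Cl)c2)nn1)C(F)(F)F`: 22700 nM
compound 3 `CCOC(=O)C1=Cc2ccccc2OC1(OCc1cn(-c2cccc(C(F)(F)F)c2)nn1)C(F)(F)F`: > 150000 nM

Compound 3 sits at the weak end: its value in this assay is a limit, not a number, (the limit of > 150000 nM in this assay, at which 1 of the 3 values shown sits). Compound 4 `CCOC(=O)C1=Cc2ccccc2OC1(OCc1cn(-c2ccc([N+](=O)[O-])cc2)nn1)C(F)(F)F` carries the change (4-nitrophenyl in place of 3-(trifluoromethyl)phenyl on an aromatic nitrogen). Within the data shown here, two measured steps bear on it. Replacing the (cyclohexylcarbamoyl)methyl group with an aryl ring gave a 2.0-fold higher number from compound 1 to compound 2 (0.30 log units; within the scatter) and an at least 13-fold higher number from compound 1 to compound 3 (1.11 log units; beyond the scatter), and between the two aryl compounds an at least 6.6-fold higher number from compound 2 to compound 3 (0.82 log units; beyond the scatter). Compound 4 keeps an aryl ring on that nitrogen, so compound 4 is expected to remain weak, with a step of about an at least 1.5-fold lower number from compound 3 to compound 4 (0.17 log units; that floor lies within the scatter), close to none beyond the scatter. Compound 4 is estimated at 100000 nM, between 25000 nM and 400000 nM.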

Compound 4, half-maximal inhibitory concentration: > 150000 nM
Compound 4: only a limit was reported; the forecaster's own chance of this, stated with the estimate: 50%; middle value at least 1.5-fold (0.17 log units) from the limit.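

In this assay, 4-nitrophenyl on this aromatic nitrogen gives an at least 6.6-fold higher number from compound 2 to compound 4 (0.82 log units; beyond the scatter) and an at least 13-fold higher number from compound 1 to compound 4 (1.11 log units; beyond the scatter). The loss seen with 3-(trifluoromethyl)phenyl is therefore not confined to that one aryl group, though compound 2, with 3-chloro-4-fluorophenyl, goes against any rule covering all aryl groups here. Compound 3 and compound 4 each give only a limit, so the step between them cannot be read: the limit of > 150000 nM in this assay, at which 2 of the 4 values shown sit.

Still open, as far as these compounds go, is how far compound 3 and compound 4 actually lie from each other. From the compounds shown here alone, it is also open whether an amine or a carboxylic acid on the aryl ring, or a longer chain in its place, would give a measured value.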